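Acid to anilide step in a series at the assay limit

A few compounds are considered here, and "the series" means these few. Any claim that something is new, unique, unknown or untested is made for them only; others in the source may bear on it.

Compound 1 `C=CC1=C(C(=O)O)C(c2ccc(F)cc2)OC1` stands only at a limit: in a functional assay on QGY7701 cells (Homo sapiens) for cytotoxicity, read by MTT assay, with a stated time of 24 h (on this read-out lower numbers stand for stronger inhibition and higher numbers for weaker inhibition), compound 1 gives > 100000 nM, a limit of the assay and not a number. Compound 2 `C=CC1=C(C(=O)O)C(c2ccc(OC)cc2)OC1` likewise gives a limit, > 100000 nM, in this assay. Compound 3 `C=CC1=C(C(=O)NC(C)(C)C)C(c2ccc(Cl)c(Cl)c2)OC1` also reaches only a limit, > 100000 nM, in this assay. The step from compound 1 to compound 2 is therefore unreadable, a step that the two limits leave unreadable from compound 1 to compound 2, and all three values sit together at the same boundary (the limit of > 100000 nM in this assay, at which 3 of the 3 values shown sit). Compound 4 `C=CC1=C(C(=O)Nc2ccc(C)cc2)C(c2ccc(F)cc2)OC1` differs from compound 1 by (4-methylphenyl)amino in place of hydroxy on a carbonyl carbon. Going by the values given here, no measured step reads a change at this position; the one amide measured, compound 3, gives a limit as well. Compound 4 is accordingly expected near the limit, with the step estimated as a number no higher from compound 1 to compound 4 (the limit leaves the size open). The estimate for compound 4 is 100000 nM, between 20000 nM and 500000 nM.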

Compound 4, half-maximal inhibitory concentration: 59200 nM
Estimate against measurement, compound 4: 1.7-fold (0.23 log units) above; the measured number falls inside the stated range.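

On the carbonyl carbon, (4-methylphenyl)amino in place of hydroxy yields the only number shown in this assay, with an at least 1.6-fold lower number from compound 1 to compound 4 (0.22 log units; that floor lies within the scatter). Going by these compounds, the true size of this step stays open, since its starting point is a limit and its floor does not clear the scatter. The series therefore remains almost entirely one-sided: the limit of > 100000 nM in this assay, at which 3 of the 4 values shown sit.

Whether the methyl group matters is open, and phenylamino on the same carbonyl carbon would address this. So is whether a benzylamino group or a longer alkyl chain on the amide nitrogen would lower the number further.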